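Fluoro for methyl on two amide cores

The compounds below may be only part of what the source reports. "The series", "measured", "known", "first", "only" and "open" are said of these compounds alone.

Two cores carry the same amide side chain. Compound 1 `C/C(=C\c1ccc(-c2ccc(C)cc2)o1)C(N)=O` and compound 2 `C/C(=C\c1ccc(-c2ccc(F)cc2)o1)C(N)=O` share the first core; compound 3 `C/C(=C\c1cc(-c2ccc(C)cc2)cs1)C(N)=O` and the unmeasured compound 4 `C/C(=C\c1cc(-c2ccc(F)cc2)cs1)C(N)=O` share the second. The difference between the two cores is not broken down here.

In an ADME assay on NIH3T3 cells (Mus musculus) for cytotoxicity, read by CCK-8 assay, with a stated time of 24 h (a lower number here means a stronger inhibitor, a higher number a weaker inhibitor), compound 1 reaches only a limit of the assay, > 50000 nM. In this assay compound 2 gives 960 nM. The change between them is fluoro in place of methyl on an aromatic carbon, and it made an at least 52-fold lower number from compound 1 to compound 2 (1.71 log units; beyond the scatter). This step is known only as a lower bound because the limit of > 50000 nM in this assay, at which 2 of the 3 values shown sit, covers compound 1. In this assay compound 3 likewise sits at a limit of the assay, > 50000 nM.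

The change from compound 3 to compound 4 is fluoro in place of methyl on an aromatic carbon, the same change as on the first core, at a place described in the same words. Going by the values given here, only one measured example of it exists, and its true size is open since compound 1 is a limit. The step is expected to run the same way, an at least 25-fold lower number from compound 3 to compound 4 (1.39 log units; beyond the scatter), resting on an at least 52-fold lower number from compound 1 to compound 2 (1.71 log units; beyond the scatter). Compound 4 is therefore estimated at 2000 nM in this assay, with an expected range from 400 nM to 20000 nM. Whether the second core carries the change as strongly as the first remains to be measured.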

Compound 4, half-maximal inhibitory concentration: > 50000 nM
Compound 4: no number, only a limit (the forecaster's own chance of this, stated with the estimate: 25%); middle value at least 25-fold (1.39 log units) away from the limit.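

In this assay compound 4 gives only a limit of the assay, > 50000 nM. Compound 3 also sits at a limit, so no step can be read between compound 3 and compound 4: the limit of > 50000 nM in this assay, at which 3 of the 4 values shown sit.

The compounds shown leave open where the true values of compound 3 and compound 4 lie, and whether fluoro in place of methyl changes anything on this core.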